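Hydroxyphenyl placement on the anilino nitrogen of the quinazoline series

The source may report more compounds than this note shows. Statements on the series, on what has been measured and on what is new or still open speak of the compounds shown alone.

Measured so far:
compound 1 `Fc1cccc(-c2nc(Nc3ccccc3F)c3cc(F)ccc3n2)c1` — in a functional assay on U2OS cells (Homo sapiens) for cytotoxicity, read by MTT assay, with a stated time of 48 h (a higher number here means a weaker inhibitor, a lower number a stronger inhibitor), compound 1 gives > 50000 nM, which is a limit of the assay.
compound 2 `Oc1cccc(Nc2nc(-c3cccc(F)c3)nc3ccc(F)cc23)c1` — in this assay compound 2 gives 33300 nM.

Among the compounds with values here, compound 2 holds the only actual number in this assay; the other value is a limit (the limit of > 50000 nM in this assay, at which 1 of the 2 values shown sits). Within the data shown here, the one measured step, an at least 1.5-fold lower number from compound 1 to compound 2 (0.17 log units; that floor lies within the scatter), only shows that a 3-hydroxyphenyl brings the number under that limit. Compound 3 `Oc1ccccc1Nc1nc(-c2cccc(F)c2)nc2ccc(F)cc12` carries the change (2-hydroxyphenyl in place of 3-hydroxyphenyl on a nitrogen on an aromatic ring). Among the measured compounds shown here, no measured step covers a shift of the hydroxyl within the ring, so for compound 3 the expected step in this assay is a 1.1-fold higher number from compound 2 to compound 3 (0.06 log units; within the scatter), none beyond the scatter. Compound 3 is estimated at 38000 nM, with a range of 14000 nM to 100000 nM.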

Compound 3, half-maximal inhibitory concentration: 41400 nM
Estimate against measurement, compound 3: 1.1-fold (0.04 log units) below, and the stated range covers the measured number.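

In this assay, 2-hydroxyphenyl in place of 3-hydroxyphenyl on this nitrogen gives a 1.2-fold higher number from compound 2 to compound 3 (0.09 log units; within the scatter), so the two hydroxyl placements cannot be told apart. Hydroxy in place of fluoro on an aromatic carbon gives an at least 1.2-fold lower number from compound 1 to compound 3 (0.08 log units; that floor lies within the scatter), and this too does not separate the two compounds. Compound 1 stands at a limit, which leaves that step a floor only: the limit of > 50000 nM in this assay, at which 1 of the 3 values shown sits.

From the compounds shown here alone, whether an aminophenyl or a carboxyphenyl on this nitrogen would bring the number clearly lower stays open. So does any effect of replacing the 3-fluorophenyl group on the shared core.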